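The source may report more compounds than this note shows. Statements on the series, on what has been measured and on what is new or still open speak of the compounds shown alone.

- Compound 1 `C=C1[C@@H](O)[C@H](n2cnc3c(O)nc(N)nc32)O[C@@H]1CO`: > 200000 nM
- Compound 2 `C=C1[C@H](n2cnc3c(Cl)nc(N)nc32)O[C@H](CO)[C@H]1O`: 10000 nM

For the measured compounds named here, in a functional assay on L1210 cells (Mus musculus) for inhibition (on this read-out higher numbers stand for weaker inhibition and lower numbers for stronger inhibition), compound 2 gives 10000 nM, the only true number so far. Compound 1 reads > 200000 nM, which is a limit of the assay and not a number. Compound 3 `C=C1[C@H](n2cnc3c(N)nc(N)nc32)O[C@H](CO)[C@H]1O` differs from compound 2 in one place: amino in place of chloro on an aromatic carbon. Going by the values given here, no measured pair shows this change, so any forecast is a judgement, and the only other guide is the limit reached by compound 1 at > 200000 nM. A move towards weaker inhibition is expected, estimated as a 4.0-fold higher number from compound 2 to compound 3 (0.60 log units; beyond the scatter). For compound 3 the expected value is 40000 nM, with an estimated range of 10000 nM to 200000 nM.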

Compound 3, half-maximal inhibitory concentration: 8200 nM
Compound 3: the middle estimate sits 4.9-fold (0.69 log units) above what was measured, outside the stated range (below it).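

Putting amino in place of chloro on this aromatic carbon gives a 1.2-fold lower number from compound 2 to compound 3 (0.09 log units; within the scatter) in this assay. The swap adds a hydrogen-bond donor and a hydrogen-bond acceptor, yet the read-out does not separate compound 2 and compound 3, so at this position the two groups cannot be told apart. Nothing measured here explains why they read alike.

As far as these compounds go, whether a methoxy group or a longer chain such as propylamino on the same carbon would also read alike stays open. One pair cannot show a general trend for this position.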